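The source may report more compounds than this note shows. Statements on the series, on what has been measured and on what is new or still open speak of the compounds shown alone.

Measured compounds in a functional assay on cells (Cancer cell lines, Homo sapiens) for inhibition; on this read-out higher numbers stand for weaker inhibition of growth and lower numbers for stronger inhibition of growth:
- compound 1 `Cc1cc(-c2nc3sc(C)cn3c2/C=N/NC(=N)N)c(C)s1`: 8320 nM
- compound 2 `Cc1cn2c(/C=N/NC(=N)N)c(-c3cccs3)nc2s1`: 4270 nM
- compound 3 `Cc1cc(-c2nc3n(c2/C=N/NC(=N)N)CCS3)c(C)s1`: 18600 nM

Compound 3 gives the highest number of the three; its gaps to compound 1 and compound 2 are both beyond the scatter. Compound 1 and compound 2 differ by thiophen-2-yl in place of 2,5-dimethylthiophen-3-yl on an aromatic carbon, and this step gives a 1.9-fold lower number from compound 1 to compound 2 (0.29 log units; within the scatter). How the core of compound 3 differs from the core of compound 1 is not broken down here.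

Compound 4 `N=C(N)N/N=C/c1c(-c2cccs2)nc2n1CCS2` is not yet measured. It differs from compound 3 by thiophen-2-yl in place of 2,5-dimethylthiophen-3-yl on an aromatic carbon, the same kind of change as from compound 1 to compound 2, though here the place is also two ring bonds from two ring atoms that each bear a fused ring. Because the earlier step of a 1.9-fold lower number from compound 1 to compound 2 (0.29 log units; within the scatter) stayed within the scatter, the expected step of a 1.9-fold lower number from compound 3 to compound 4 (0.27 log units; within the scatter) is estimated to be of similar size. Compound 4 is expected to give about 10000 nM, between 4500 nM and 22000 nM.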

Compound 4, concentration for 50% growth inhibition: 19100 nM
The estimate for compound 4 lay 1.9-fold (0.28 log units) below the measured number, within the range that was stated.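

In this assay thiophen-2-yl in place of 2,5-dimethylthiophen-3-yl gives a 1.0-fold higher number from compound 3 to compound 4 (0.01 log units; within the scatter), so on this core too the change stays within the scatter. Set beside the earlier step, the change carries from one core to the other without a difference that can be told from the scatter: the same change on two cores in this assay, a 1.9-fold lower number (0.29 log units; within the scatter) from compound 1 to compound 2 and a 1.0-fold higher number (0.01 log units; within the scatter) from compound 3 to compound 4, 2.0-fold (0.30 log units) apart, within the scatter of two such steps. This shows agreement between two cores for this one change, but with both steps inside the scatter it does not show that the change has any real effect on the read-out, nor that the agreement would hold on a further core.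

The compounds shown leave open whether a group other than a thiophene on this aromatic carbon, such as a phenyl ring or a ring carrying an amine or a carboxylic acid, would move the number beyond the scatter.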